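The compounds below may be only part of what the source reports. "The series", "measured", "known", "first", "only" and "open" are said of these compounds alone.

Measured compounds:
Compound 1 `COc1ccccc1-c1ccc(Nc2nc(N[C@H]3CC[C@H](N)CC3)nc3c2ncn3C2CCCC2)cc1` gives 2320 nM in a functional assay on K562 cells (Homo sapiens) for inhibition, read by fluorescence and resazurin assay, with a stated time of 72 h; on this read-out higher numbers stand for weaker inhibition of growth and lower numbers for stronger inhibition of growth.
Compound 2 `Nc1ccccc1-c1ccc(Nc2nc(N[C@H]3CC[C@H](N)CC3)nc3c2ncn3C2CCCC2)cc1` gives 1070 nM in this assay.
Compound 3 `N[C@H]1CC[C@H](Nc2nc(Nc3ccc(-c4cccs4)nc3)c3ncn(C4CCCC4)c3n2)CC1` gives 574 nM in this assay.

Of these three numbers, compound 3 has the lowest. Its nearest neighbour is compound 2, whose number is higher but only within the scatter, so no order between compound 2 and compound 3 can be claimed; compound 1 stands furthest away, with a higher number beyond the scatter.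

Among the compounds with values here, the one step that can be followed between measured compounds is a 2.2-fold lower number from compound 1 to compound 2 (0.34 log units; beyond the scatter), a modest step. It concerns a substituent on the outer phenyl ring and does not touch the aryl group itself, so it gives no direct guide for what follows.

Compound 4 `COc1ccc(-c2ccc(Nc3nc(N[C@H]4CC[C@H](N)CC4)nc4c3ncn4C3CCCC3)cn2)cc1` differs from compound 3 in one place: 4-methoxyphenyl in place of thiophen-2-yl on an aromatic carbon. Within the data shown here, no measured pair shows this kind of exchange, so the expectation rests on the spread of the three numbers, within which compound 1, carrying a methoxyphenyl, has the highest number. A step of a 1.6-fold higher number from compound 3 to compound 4 (0.20 log units; within the scatter) towards a somewhat higher number is therefore expected, though one that may stay within the scatter. Compound 4 is estimated at 900 nM, with a range from 350 nM to 2500 nM.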

Compound 4, concentration for 50% growth inhibition: 698 nM
Estimate against measurement, compound 4: 1.3-fold (0.11 log units) above; the range from low to high includes it.
By their numbers in this assay, from the lowest: compounds 3, 4 and 2 (each within the scatter of the next); then compound 1.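

At the aromatic carbon next to the ring nitrogen, para to a large group, this assay shows a 1.2-fold higher number from compound 3 to compound 4 (0.08 log units; within the scatter) on exchanging thiophen-2-yl for 4-methoxyphenyl, so compound 3 and compound 4 cannot be placed in any order. Until now the compounds gave no exchange of this outer aryl group on an otherwise unchanged structure; this pair shows that a six-membered aromatic ring of carbon only with 8 heavy atoms can stand where a five-membered aromatic ring with 5 heavy atoms stood, with the number staying within the scatter. Nothing available here accounts for this result.

Within the data shown here, the single pair covers only two neutral aryl groups, so it leaves open whether a piperazine, a carboxylic acid or a morpholine on the outer ring would also leave the number within the scatter. It also leaves open whether amino in place of methoxy, which gave a 2.2-fold lower number from compound 1 to compound 2 (0.34 log units; beyond the scatter) in another setting, would give a similar step when made on compound 4.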